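From pyridin-3-yl to pyridin-4-yl in compound 1

This account rests on a few compounds, and the source may have more. Where it says the series, first, only, none or still open, it means among the compounds named here.

compound 1 (`CN1C/C(=C\c2cccnc2)C(=O)/C(=C/c2ccc(F)cc2Br)C1`) gives 20800 nM
compound 2 (`CN1C/C(=C\c2ccc(C#N)cc2)C(=O)/C(=C/c2cccnc2)C1`) gives 13600 nM

Both numbers come from one test (a functional assay on SMMC-7721 cells (Homo sapiens) for cytotoxicity, read by MTT assay, with a stated time of 24 h; a higher number here means a weaker inhibitor, a lower number a stronger inhibitor), and compound 1 stands within the scatter of compound 2. Compound 3 (`CN1C/C(=C\c2ccncc2)C(=O)/C(=C/c2ccc(F)cc2Br)C1`) is unmeasured. It carries pyridin-4-yl in place of pyridin-3-yl on a double-bonded chain carbon bound to a double-bonded ring carbon. Within the data shown here, the only measured step (a 1.5-fold lower number from compound 1 to compound 2 (0.18 log units; within the scatter)) exchanges a different group and stays within the scatter, so it offers no direct evidence on this change. Thus in this assay no step beyond the scatter is expected, in either direction. The expected result is a small step (a 1.1-fold lower number from compound 1 to compound 3 (0.04 log units; within the scatter)). Compound 3 is estimated at 19000 nM with an expected range from 9000 nM to 40000 nM (a forecast only).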

Compound 3, half-maximal inhibitory concentration: 23800 nM
Estimate against measurement, compound 3: 1.3-fold (0.10 log units) below, and the stated range covers the measured number.
By their numbers in this assay, from the lowest: compounds 2, 1 and 3 (each within the scatter of the next).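

In this assay, placing pyridin-4-yl in place of pyridin-3-yl on a double-bonded chain carbon bound to a double-bonded ring carbon gives only a small step (a 1.1-fold higher number from compound 1 to compound 3 (0.06 log units; within the scatter)). Among these compounds, this is the first direct reading of this change, and at this place the two pyridine groups cannot be told apart. No measurement shown explains this result. Still open, as far as these compounds go, is whether pyridin-2-yl would read the same here, and whether a group of another kind at this place, such as an amine or a carboxylic acid, would move the number beyond the scatter.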